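The source may hold more compounds than are shown below. What is called first, only, known or untested is meant among the compounds shown, and "the series" means these compounds.

Measured so far in a functional assay on Jurkat cells (Homo sapiens); a lower number here means a stronger inhibitor, a higher number a weaker inhibitor:
compound 1 `CC(C)[C@H](NC(=O)COc1cccc2ccccc12)C(=O)N[C@@H](CC(=O)O)C(=O)COc1cc(C(F)(F)F)cc(C(F)(F)F)c1`: > 100000 nM
compound 2 `CC(C)[C@H](NC(=O)COc1cccc2ccccc12)C(=O)N[C@@H](CC(=O)O)C(=O)COc1ccc([N+](=O)[O-])cc1`: > 100000 nM
compound 3 `CC(C)[C@H](NC(=O)COc1cccc2ccccc12)C(=O)N[C@@H](CC(=O)O)C(=O)COc1c(F)c(F)c(-c2c(F)c(F)c(F)c(F)c2F)c(F)c1F`: 20000 nM

The value for compound 1 is a limit of this assay, not a number. The value for compound 2 is likewise a limit, not a number. Compound 2 thus stands at the weak end of the numbers shown, at the limit of > 100000 nM in this assay, at which 2 of the 3 values shown sit. Only compound 3 gives a number, and that one is weak.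

Compound 4 `CC(C)[C@H](NC(=O)COc1cccc2ccccc12)C(=O)N[C@@H](CC(=O)O)C(=O)COc1ccc([N+](=O)[O-])cc1F` is not yet measured. It differs from compound 2 by fluoro in place of hydrogen on an aromatic carbon. Within the data shown here, no step between measured compounds is known, so the size of such a step cannot be read from the series, and compound 3 with its heavily fluorinated aryl gives no guide to a single fluoro. The step of a number no higher from compound 2 to compound 4 (the limit leaves the size open) is expected to be none beyond the scatter, most likely ending in another limit. Compound 4 is estimated at 100000 nM, within 30000 nM to 300000 nM.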

Compound 4, half-maximal inhibitory concentration: 30300 nM
Estimate against measurement, compound 4: 3.3-fold (0.52 log units) above; the measured number falls inside the stated range.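

In this assay the change from 4-nitrophenoxy to 2-fluoro-4-nitrophenoxy gives an at least 3.3-fold lower number from compound 2 to compound 4 (0.51 log units; beyond the scatter). A single fluoro on this aromatic carbon, ortho to a large group, is thus enough to turn a limit into a number, although compound 4 remains a weak inhibitor. The value of compound 2 is a limit, not a number, so the true size of the step stays open: the limit of > 100000 nM in this assay, at which 2 of the 4 values shown sit.

As far as these compounds go, whether a chloro or a methyl at the same position would act as fluoro does remains open. Also open, from the compounds shown here alone, is whether fluoro would give a similar step on the aryl of compound 1.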